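Sulfonylamino to hydroxy: expected drop in lipophilicity

The compounds below may be only part of what the source reports. "The series", "measured", "known", "first", "only" and "open" are said of these compounds alone.

Measured compounds:
compound 1 `CCC(CNC(=O)c1ccc2c(c1)c(Cc1ccc(C(=O)O)cc1OC)cn2C)CC(F)(F)F` 5.53
compound 2 `COc1cc(C(=O)NS(=O)(=O)c2ccccc2C)ccc1Cc1cn(C)c2ccc(C(=O)NCC(C)CC(F)(F)F)cc12` 6.18
compound 3 `CCC(CNC(=O)c1ccc2c(c1)c(Cc1ccc(C(=O)NS(=O)(=O)c3ccccc3C)cc1OC)cn2C)CC(F)(F)F` 6.45

Of the compounds shown here, three have been measured in a physicochemical assay for lipophilicity; on this read-out lower numbers stand for lower lipophilicity and higher numbers for higher lipophilicity. Compound 3 gives 6.45, and compound 1 gives 5.53. The difference between them is hydroxy in place of ((2-methylphenyl)sulfonyl)amino on a carbonyl carbon, and that change made a step of a number 0.92 log units lower from compound 3 to compound 1 (beyond the scatter). Compound 2 gives 6.18; it differs from compound 3 in the core, as hydrogen in place of methyl on a saturated chain carbon, three bonds along the chain from an amide-type nitrogen, and that step was a number 0.27 log units higher from compound 2 to compound 3 (within the scatter).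

Compound 4 `COc1cc(C(=O)O)ccc1Cc1cn(C)c2ccc(C(=O)NCC(C)CC(F)(F)F)cc12` is not yet measured. It differs from compound 2 as hydroxy in place of ((2-methylphenyl)sulfonyl)amino on a carbonyl carbon. This is the same change that was made from compound 3 to compound 1, at the same place, and the cores of compound 2 and compound 3 differ only as described. On the strength of compound 2 at 6.18 and the step seen from compound 3 to compound 1 of a number 0.92 log units lower from compound 3 to compound 1 (beyond the scatter), compound 4 is expected to move by about a number 0.92 log units lower from compound 2 to compound 4 (beyond the scatter) from compound 2. Compound 4 is therefore estimated at 5.26, with a likely range from 4.86 to 5.66.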

Compound 4, partition coefficient: 5.12
Compound 4: middle estimate off by 0.14 log units, on the high side; low and high end bracket the measured number.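

In this assay, hydroxy in place of ((2-methylphenyl)sulfonyl)amino on a carbonyl carbon gave a number 1.06 log units lower from compound 2 to compound 4 (beyond the scatter), in the same direction as a number 0.92 log units lower from compound 3 to compound 1 (beyond the scatter), and with both steps beyond the scatter, the change carried from one core to the other. The two cores do not stay equally close with each group in place: with the ((2-methylphenyl)sulfonyl)amino group they differ by a number 0.27 log units higher from compound 2 to compound 3 (within the scatter), whereas with hydroxy the matching step is a number 0.41 log units lower from compound 1 to compound 4 (beyond the scatter). This is a single pair of cores, so it does not show that the step would hold on any other core, and nothing measured here bears on what lies behind it.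

The compounds shown leave open whether an amine in place of the hydroxy on that carbonyl carbon would give a step of similar direction and size. They also leave open how a longer chain on the saturated chain carbon would fit the pattern on either side of the change.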